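The source may hold more compounds than are shown below. What is called first, only, known or untested is meant among the compounds shown, and "the series" means these compounds.

Among the compounds with values here, compound 1 `Cc1nc(NC(=O)c2ccccc2)sc1C(=O)/C=C/c1ccc(F)cc1` is one of three compounds measured in an assay for inhibition of Polyunsaturated fatty acid 5-lipoxygenase (Homo sapiens), read by spectrophotometry, tested at 10 uM, in the presence of a further agent that is not named here (a higher number here means more inhibition at the concentration tested (going by the name of the read-out), a lower number less inhibition), and in it compound 1 gives 98%. Compound 2 `COc1ccc(C(=O)Nc2nc(C)c(C(=O)/C=C/c3ccc(C)cc3)s2)cc1` gives 100%, and compound 3 `Cc1nc(NC(=O)c2ccccc2)sc1C(=O)/C=C/c1ccc(N(C)C)cc1` gives 88.2%. Compound 1 thus stands second highest of the three numbers, with compound 2 nearest and compound 3 furthest, both gaps lying within the scatter. Within the data shown here, the only step between compounds differing in a single place is a number 9.8 percentage points lower from compound 1 to compound 3 (within the scatter).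

Compound 4 `Cc1nc(NC(=O)c2ccccc2)sc1C(=O)/C=C/c1ccco1` has not yet been measured in this assay. It differs from compound 1 in one place: furan-2-yl in place of 4-fluorophenyl on a double-bonded chain carbon bound to a double-bonded chain carbon. Among the measured compounds shown here, no measured step exchanges this ring itself; the one step that bears on this end of the molecule, the step from compound 1 to compound 3, stays within the scatter. Because compound 3 still gives 88.2%, compound 4 is expected to remain in the same high region. The expected step is a number 6 percentage points lower from compound 1 to compound 4 (within the scatter), not beyond the scatter. Compound 4 is therefore estimated at 92%, within a range from 72% to 100%.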

Compound 4, a percentage reported as inhibition, at one concentration (the size of the read-out at that concentration, not a potency): 57.2%
Estimate against measurement, compound 4: 34.8 percentage points above; the measured number lies below the stated range.
By their numbers in this assay, from the lowest: compound 4; then compounds 3, 1 and 2 (each within the scatter of the next, the first and the last beyond it).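

In this assay, the group on this double-bonded chain carbon proves able to change the result: the step is a number 40.8 percentage points lower from compound 1 to compound 4 (beyond the scatter), and likewise a number 31 percentage points lower from compound 3 to compound 4 (beyond the scatter). Within the data shown here, the earlier step between 4-fluorophenyl and 4-(dimethylamino)phenyl, both six-membered aromatic rings of carbon only, had stayed within the scatter, whereas furan-2-yl in place of either group gives the first large step at this position. Nothing available explains this loss of inhibition.

The compounds shown leave open whether the step follows the smaller ring or its oxygen atom, and thiophen-2-yl or unsubstituted phenyl at the same place would help separate the two. They also leave open how the potencies compare, as each number is a read-out at one concentration.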